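The compounds below may be only part of what the source reports. "The series", "measured", "known", "first", "only" and "open" are said of these compounds alone.

Measured so far:
compound 1, `Cc1ccc(NC(=O)c2cnc(Cl)nc2C(F)(F)F)s1`: 2300 nM
compound 2, `O=C(Nc1cc(C(F)(F)F)cc(C(F)(F)F)c1)c1cnc(Cl)nc1C(F)(F)F`: 50 nM

In an assay on Jurkat cells for inhibition of nuclear factor NF-kappa-B p105 subunit (Homo sapiens) (on this read-out higher numbers stand for weaker inhibition and lower numbers for stronger inhibition), compound 1 gives 2300 nM and compound 2 gives 50 nM. Compound 2 holds the lowest number of the two; the gap to compound 1 lies beyond the scatter. Within the data shown here, no step between measured compounds differing in a single place is known, so the series offers no direct guide for the next change.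

Compound 3, `CCOC(=O)c1cc(NC(=O)c2cnc(Cl)nc2C(F)(F)F)cc(C(F)(F)F)c1`, has not been measured in this assay. It differs from compound 2 by ethoxycarbonyl in place of trifluoromethyl on an aromatic carbon. Nothing measured speaks to this kind of exchange, so the expectation rests on compound 2 alone: a modest weakening is expected, a step of a 3.0-fold higher number from compound 2 to compound 3 (0.48 log units; beyond the scatter) in this assay, of a size that may or may not exceed the scatter. Compound 3 is expected at 150 nM, within 40 nM to 600 nM.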

Compound 3, half-maximal inhibitory concentration: 280 nM
Compound 3: the middle estimate sits 1.9-fold (0.27 log units) below what was measured; the measured number falls inside the stated range.
By their numbers in this assay, from the lowest: compound 2; then compound 3; then compound 1.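

Among these compounds, the first single-place step falls on an aromatic carbon meta to a trifluoromethyl group: in this assay, ethoxycarbonyl in place of trifluoromethyl gives a 5.6-fold higher number from compound 2 to compound 3 (0.75 log units; beyond the scatter) and is a modest loss. The position therefore responds to this exchange, although compound 3 still reads 280 nM with a larger group and with hydrogen-bond acceptors where trifluoromethyl had none. No measurement available bears on which of these differences matters.

Open, as far as these compounds go, is whether the ester itself or simply the loss of trifluoromethyl sets the size of the step. A carboxylic acid, a primary amide or a bare hydrogen on this carbon would separate those readings, and a methyl ester would show whether the ethyl part contributes.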